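The compounds below may be only part of what the source reports. "The series", "measured", "known", "first", "only" and "open" are said of these compounds alone.

Values measured in an in vitro ADME assay on microsomes (Mus musculus) for metabolic stability (on this read-out lower numbers stand for a shorter-lived compound and higher numbers for a longer-lived compound), follow.

- Compound 1 `CNC(=O)Nc1ccc(-c2nc(N3CC4CCC(C3)O4)c3cnn(CCN(C)C)c3n2)cc1` gives 0.0833 h
- Compound 2 `O=C(Nc1ccc(-c2nc(N3CC4CCC(C3)O4)c3cnn(C4CCC5(CC4)OCCO5)c3n2)cc1)Nc1cccnc1` gives > 0.5 h
- Compound 3 `CNC(=O)Nc1ccc(-c2nc(N3CC4CCC(C3)O4)c3cnn([C@H]4CC[C@@H](OC)CC4)c3n2)cc1` gives 0.283 h

Compound 2 stands at the limit of > 0.5 h in this assay, at which 1 of the 3 values shown sits, which is a limit and not a number. Compound 4 `O=C(Nc1ccc(-c2nc(N3CC4CCC(C3)O4)c3cnn(C4CCC5(CC4)OCCO5)c3n2)cc1)NC1CC1` differs from compound 2 in one place (cyclopropyl in place of pyridin-3-yl on an amide-type nitrogen), with cyclopropyl in place of pyridin-3-yl on an amide-type nitrogen. For the measured compounds named here, the only measured step, a 3.4-fold higher number from compound 1 to compound 3 (0.53 log units; beyond the scatter), lies on an aromatic nitrogen, so it bears on this change only indirectly. Without pyridin-3-yl, compound 1 gives 0.0833 h and compound 3 gives 0.283 h, though both also differ from compound 2 elsewhere. A modest fall is therefore expected, and the expected step is an at least 1.4-fold lower number from compound 2 to compound 4 (0.15 log units; that floor lies within the scatter). For compound 4 the estimated half-life is 0.35 h, with an expected range of 0.12 h to 0.7 h.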

Compound 4, half-life: 0.417 h
Estimate against measurement, compound 4: 1.2-fold (0.08 log units) below; the measured number falls inside the stated range.
By their numbers in this assay, from the lowest: compound 1; then compounds 3 and 4 (each within the scatter of the next). At a limit, above all of these: compound 2.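

In this assay, this is the first change shown on the amide-type nitrogen rather than the aromatic nitrogen, and cyclopropyl in place of pyridin-3-yl gives an at least 1.1-fold lower number from compound 2 to compound 4 (0.07 log units; that floor lies within the scatter). That floor shows no firm loss, and it cannot show the true size of the step, which stays unknown for compound 2 as it has only a limit: the limit of > 0.5 h in this assay, at which 1 of the 4 values shown sits.

On these data alone, how a longer carbon chain, an amine or a carboxylic acid on this nitrogen would change the half-life stays open. So does whether this swap would read the same with 4-methoxycyclohexyl on the aromatic nitrogen.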